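This account rests on a few compounds, and the source may have more. Where it says the series, first, only, none or still open, it means among the compounds named here.

In a functional assay on OVCAR-3 cells (Homo sapiens) for antiproliferative activity, read by MTT assay, with a stated time of 24 h (on this read-out lower numbers stand for stronger inhibition and higher numbers for weaker inhibition), compound 1 `Cc1ccccc1NNC(=O)c1cccc(NS(=O)(=O)c2cnc(O)nc2O)c1` gives only a limit, > 20000 nM. Compound 2 `O=C(NNc1cccc(Cl)c1)c1cccc(NS(=O)(=O)c2cnc(O)nc2O)c1` gives a true number, 8040 nM. Compound 3 `Cc1ccccc1C(=O)NNC(=O)c1cccc(NS(=O)(=O)c2cnc(O)nc2O)c1` is also only a limit, > 20000 nM, and so belongs to the limit of > 20000 nM in this assay, at which 2 of the 3 values shown sit.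

Compound 4 `O=C(NNC(=O)c1cccc(NS(=O)(=O)c2cnc(O)nc2O)c1)c1ccc(F)cc1` differs from compound 3 in one group: 4-fluorophenyl in place of 2-methylphenyl on a carbonyl carbon. The readable steps, an at least 2.4-fold lower number from compound 1 to compound 2 (0.39 log units; beyond the scatter) and an at least 2.4-fold higher number from compound 2 to compound 3 (0.39 log units; beyond the scatter), both change the group on an amine nitrogen rather than the one on a carbonyl carbon, so they bear on this swap only loosely. Among the compounds with values here, no measured step shows a direction for it.

The expected result is therefore little movement, a step that the limit leaves unreadable from compound 3 to compound 4. Compound 4 is estimated at 22000 nM, within an expected range of 9000 nM to 50000 nM.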

Compound 4, half-maximal inhibitory concentration: > 20000 nM
Compound 4: no number, only a limit; the forecaster's own chance of this, stated with the estimate: 75%; the middle value is on the limit's open side.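

Placing 4-fluorophenyl instead of 2-methylphenyl on the carbonyl carbon still gives no true number in this assay: compound 4 gives only a limit. Within the data shown here, the carbonyl-linked series now has two different aryl groups at this limit, while the one true number stays with the 3-chlorophenyl compound, with an at least 2.4-fold higher number from compound 2 to compound 4 (0.39 log units; beyond the scatter). The steps among compound 1, compound 3 and compound 4 cannot be read, and the limit is now the commonest result: the limit of > 20000 nM in this assay, at which 3 of the 4 values shown sit.

From the compounds shown here alone, whether a 3-chlorophenyl, a methyl or an amine on that carbonyl carbon would give a true number stays open. So does any real difference hidden behind the shared limit.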